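This account rests on a few compounds, and the source may have more. Where it says the series, first, only, none or still open, it means among the compounds named here.

Measured so far in a functional assay on DU-145 cells (Homo sapiens) for inhibition, read by trypan blue exclusion, with a stated time of 96 h; on this read-out higher numbers stand for weaker inhibition of growth and lower numbers for stronger inhibition of growth:
Compound 1 `COc1ccc(/C=C(/SCc2ccc(F)cc2)C(=O)c2ccc(Cl)cc2)c(OC)c1OC` gives 10000 nM
Compound 2 `Cc1ccc(/C=C(/SCc2ccc(Cl)cc2)C(=O)c2ccc(Cl)cc2)s1` gives 50000 nM

Compound 1 stands lowest of the two numbers (10000 nM). Compound 2 gives 50000 nM, a gap that lies beyond the scatter. Compound 3 (`COc1ccc(/C=C(/Sc2ccccc2Cl)C(=O)c2ccc(Cl)cc2)c(OC)c1OC`) is not yet measured. Its change from compound 1 is 2-chlorophenyl in place of 4-fluorobenzyl on a sulfur. Going by the values given here, no measured pair isolates this change, so no step beyond the scatter is expected in this assay, in either direction. That expectation gives an estimated step (no change at the digits printed from compound 1 to compound 3 (within the scatter)). Compound 3 is estimated at 10000 nM (expected range 2500 nM to 40000 nM).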

Compound 3, concentration for 50% growth inhibition: 10000 nM
The estimate for compound 3 equals the measured number at the digits printed; low and high end bracket the measured number.
By their numbers in this assay, from the lowest: compounds 1 and 3 (each within the scatter of the next); then compound 2.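

In this assay, going by these compounds alone, 2-chlorophenyl in place of 4-fluorobenzyl on a sulfur gives no change at the digits printed from compound 1 to compound 3 (within the scatter) and is the first single-place comparison. At this position, the benzyl group is therefore not needed to keep the number within the scatter. No measured evidence offers an explanation for this result.

This swap alters both the halogen and the link to the ring, so the pair cannot separate the two. On these data alone, how an aminomethyl or carboxylic acid group on that ring, or a longer chain on the sulfur, would read remains open.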